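A few compounds are considered here, and "the series" means these few. Any claim that something is new, unique, unknown or untested is made for them only; others in the source may bear on it.

Working notes on the series. In a functional assay on HeLa cells (Homo sapiens) for inhibition, read by sulforhodamine B assay (on this read-out higher numbers stand for weaker inhibition and lower numbers for stronger inhibition), compound 3 (`O=C1C(NC2CCCC2)=CC(=O)c2c1nc1n2[C@H]2OC[C@@H](O)[C@H]2OC1`) gives > 16000 nM, a limit and not a number. Compound 1 (`O=C1C=C(NCc2ccccc2)C(=O)c2c1nc1n2[C@H]2OC[C@@H](O)[C@H]2OC1`) gives > 8000 nM, also a limit. Compound 2 (`O=C1C=C(N2CCC2)C(=O)c2c1nc1n2[C@H]2OC[C@@H](O)[C@H]2OC1`) gives > 16000 nM, again a limit. No measured number exists yet in this assay.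

Compound 4 (`Cc1ccc(NC2=CC(=O)c3c(nc4n3[C@H]3OC[C@@H](O)[C@H]3OC4)C2=O)cc1C`) has 3,4-dimethylphenyl in place of cyclopentyl on an amine nitrogen. Within the data shown here, the only measured step, a step that the two limits leave unreadable from compound 1 to compound 2, has no readable size and sets no direction. The expectation therefore rests on compound 3 at > 16000 nM, a limit. No change beyond the scatter is expected, and the estimated step is an at least 1.1-fold lower number from compound 3 to compound 4 (0.05 log units; that floor lies within the scatter). For compound 4 the expected value is 14000 nM, with an estimated range of 4000 nM to 40000 nM.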

Compound 4, half-maximal inhibitory concentration: 4320 nM
The estimate for compound 4 lay 3.2-fold (0.51 log units) above the measured number; measured number inside the range.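

In this assay, among these compounds, compound 4 is the first to give a measured number rather than a limit, and 3,4-dimethylphenyl in place of cyclopentyl on the amine nitrogen gives an at least 3.7-fold lower number from compound 3 to compound 4 (0.56 log units; beyond the scatter). Among the compounds shown here, this gives the change at this nitrogen a readable direction, which the earlier steps, unreadable between limits, could not provide. The size is only a floor because compound 3 carries a limit: the limit of > 16000 nM in this assay, at which 2 of the 4 values shown sit.

The compounds shown leave open whether plain phenyl, without the methyl groups, would hold this gain. They also leave open how a methoxy group or a carboxylic acid on that ring would read.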